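From naphthalen-1-yl to 4-methoxyphenyl on the shared core

The compounds below may be only part of what the source reports. "The series", "measured", "known", "first", "only" and "open" are said of these compounds alone.

For the measured compounds named here, in a functional assay on A549 cells (Homo sapiens) for antiproliferative activity, read by MTT assay, with a stated time of 48 h (on this read-out higher numbers stand for weaker inhibition and lower numbers for stronger inhibition), compound 2 `Cn1cc(C2=C(c3nn(CCCN4CCCCC4)c4ncccc34)C(=O)N(c3cccc4ccccc34)C2=O)c2ccccc21` gives 2820 nM, the lowest of the numbers available so far. Compound 1 `Cn1cc(C2=C(c3nn(CCCN4CCCCC4)c4ncccc34)C(=O)N(c3ccccc3)C2=O)c2ccccc21` stands higher, at 20600 nM. Compound 3 `Cn1cc(C2=C(c3n[nH]c4ncccc34)C(=O)NC2=O)c2ccccc21` gives no number, only a limit of the assay, > 100000 nM.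

The next compound to consider is compound 4 `COc1ccc(N2C(=O)C(c3cn(C)c4ccccc34)=C(c3nn(CCCN4CCCCC4)c4ncccc34)C2=O)cc1`, which has 4-methoxyphenyl in place of naphthalen-1-yl on an amide-type nitrogen in a ring. Going by the values given here, only one measured step bears on this change. Going from phenyl in compound 1 to naphthalen-1-yl in compound 2 at this same nitrogen gave a 7.3-fold lower number from compound 1 to compound 2 (0.86 log units; beyond the scatter), a modest step but one beyond the scatter. Compound 4 gives up naphthalen-1-yl and again carries a single aromatic ring, as compound 1 does, so most of that gain is expected to be lost. Among the compounds with values here, no measured step shows what the methoxy group adds to a phenyl group, so the expectation remains loose. In this assay, a higher number is expected, and the size of the change is estimated as a 5.0-fold higher number from compound 2 to compound 4 (0.70 log units; beyond the scatter). Compound 4 is expected to give about 14000 nM, with an estimated range from 5000 nM to 40000 nM.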

Compound 4, half-maximal inhibitory concentration: 30300 nM
The estimate for compound 4 lay 2.2-fold (0.34 log units) below the measured number, within the range that was stated.
By their numbers in this assay, from the lowest: compound 2; then compounds 1 and 4 (each within the scatter of the next). At a limit, above all of these: compound 3.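

In this assay, for the compounds shown here, the change at the amide-type nitrogen gives an 11-fold higher number from compound 2 to compound 4 (1.03 log units; beyond the scatter) and is the largest step measured at this position so far. Compared with plain phenyl, methoxy in place of hydrogen on an aromatic carbon gives a 1.5-fold higher number from compound 1 to compound 4 (0.17 log units; within the scatter) and so has no effect here that can be told from the scatter. Among the three groups now shown on this nitrogen, naphthalen-1-yl alone stands apart: compound 2 lies beyond the scatter from both compound 1 and compound 4, while the two groups with a single aromatic ring cannot be separated, which the earlier pair alone could not show.

The compounds shown leave open whether the number depends on the naphthalen-1-yl group specifically or would also fall with another two-ring group such as naphthalen-2-yl, and whether a chlorine or a dimethylamino group on the phenyl ring would separate itself from phenyl as methoxy does not. Nothing in the data shown bears on why these steps take the sizes they do.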